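The source may hold more compounds than are shown below. What is called first, only, known or untested is meant among the compounds shown, and "the series" means these compounds.

Working notes on the indole acrylate series.

Compound 1 `CCOC(=O)/C(=C/c1c[nH]c2ccccc12)C(=O)c1ccccc1` is the plain benzoyl ester. In a functional assay on MT4 cells (Homo sapiens) for antiproliferative activity, read by MTT assay, with a stated time of 96 h (on this read-out lower numbers stand for an effect already at smaller amounts and higher numbers for an effect only at larger amounts of compound), compound 1 reaches only the limit of the assay, > 100000 nM. Compound 2 `CCOC(=O)/C(=C/c1c[nH]c2ccccc12)C(=O)c1ccc([N+](=O)[O-])cc1` carries a nitro group on the benzoyl ring, and in this assay compound 2 gives 100000 nM. Among the measured compounds shown here, the one directly measured step, a number no higher from compound 1 to compound 2 (the limit leaves the size open), rests on a limit (the limit of > 100000 nM in this assay, at which 1 of the 3 values shown sits), so its size cannot be read. Compound 3 `CC(=O)/C(=C\c1c(-c2ccccc2)[nH]c2ccccc12)S(=O)(=O)c1ccccc1` differs from compound 2 in several places at once; in this assay compound 3 gives 400 nM. Of the two numbers shown, compound 2 therefore holds the higher one, and the gap down to compound 3 is beyond the scatter.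

Compound 4 `CCOC(=O)/C(=C/c1c(-c2ccccc2)[nH]c2ccccc12)C(=O)c1ccc([N+](=O)[O-])cc1` differs from compound 2 by phenyl in place of hydrogen on an aromatic carbon. For the measured compounds named here, no measured step isolates this change; the only step measured, from compound 1 to compound 2, concerns the nitro group, and the pair compound 2 and compound 3 combines the phenyl with other alterations, so only the values themselves can be read. The expected step, a 5.0-fold lower number from compound 2 to compound 4 (0.70 log units; beyond the scatter), is taken as a decrease in the number, short of what compound 3 shows. The estimate for compound 4 in this assay is 20000 nM, with a range from 2000 nM to 100000 nM.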

Compound 4, half-maximal effective concentration: 1500 nM
Estimate against measurement, compound 4: 13-fold (1.12 log units) above, and the stated range ends above it.
By their numbers in this assay, from the lowest: compound 3; then compound 4; then compound 2.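

Phenyl in place of hydrogen, on an aromatic carbon next to the ring nitrogen and next to the ring atom that bears a large group, now has a step of its own in this assay: a 67-fold lower number from compound 2 to compound 4 (1.82 log units; beyond the scatter), with the rest of compound 2 unchanged. Among the compounds shown here, until now the phenyl stood only in compound 3, together with other alterations, and the single change before it, the nitro group, gave a step that cannot be read, so this is the first change with a readable size and it belongs to this position alone. Nothing measured here gives a reason for the size of this step.

Only hydrogen and phenyl are shown at this carbon, so it stays open whether a methyl, a longer chain or a phenyl bearing an amine or a carboxylic acid would give a step of similar size. As far as these compounds go, it also stays open whether the phenyl step carries over to the plain benzoyl ester, or to a core with the ethyl ester exchanged for a nitrile.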